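Swapping Methyl for Fluoro on the Outer Ring

The source may hold more compounds than are shown below. What is called first, only, known or untested is meant among the compounds shown, and "the series" means these compounds.

Of the compounds shown here, two have so far been measured in a functional assay on SGC-7901 cells (Homo sapiens) for antiproliferative activity, read by MTT assay, with a stated time of 24 h; on this read-out lower numbers stand for stronger inhibition and higher numbers for weaker inhibition. Compound 1 `Cc1cccc(-n2cc(-c3ccccc3NS(=O)(=O)c3c[nH]c(=O)[nH]c3=O)nn2)c1` gives 3510 nM in this assay. Compound 2 `Cc1ccc(-n2cc(-c3cccc(NS(=O)(=O)c4c[nH]c(=O)[nH]c4=O)c3)nn2)cc1` gives 9430 nM, the higher of the two numbers, and its gap to compound 1 lies beyond the usual scatter, so compound 2 is the weaker inhibitor of the pair.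

Compound 3 `O=c1[nH]cc(S(=O)(=O)Nc2cccc(-c3cn(-c4ccc(F)cc4)nn3)c2)c(=O)[nH]1` has not yet been measured. It differs from compound 2 in a single place: fluoro in place of methyl on an aromatic carbon, para to a large group, so that a 4-methylphenyl becomes a 4-fluorophenyl. Among the measured compounds shown here, no measured pair shows this exact swap, so there is no step to lean on. A small exchange of this kind is expected to move the number little, if at all, with no step beyond the scatter. Compound 3 is therefore expected to give 8000 nM, with a likely range from 3000 nM to 20000 nM. The estimated step is a 1.2-fold lower number from compound 2 to compound 3 (0.07 log units; within the scatter).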

Compound 3, half-maximal inhibitory concentration: > 20000 nM
Compound 3 ended at the assay's limit; the forecaster's own chance of this, stated with the estimate: 10%; at least 2.5-fold (0.39 log units) between middle value and limit.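

On the 4-methylphenyl ring of compound 2, fluoro in place of methyl, para to a large group, gives an at least 2.1-fold higher number from compound 2 to compound 3 (0.32 log units; beyond the scatter), so exchanging this single heavy atom is enough to weaken inhibition in this assay. Compounds 1 and 2 differ in more than one place, so their values could not isolate this position or this change. In this assay compound 3 gives > 20000 nM, which is a limit of the assay and not a number, so the full size of the step stays unknown: the limit of > 20000 nM in this assay, at which 1 of the 3 values shown sits.

The compounds shown leave open whether losing the methyl or gaining the fluoro matters more, and a plain hydrogen, a chlorine atom, a methoxy group or an amine at this place could help separate the two. They also leave open whether the same swap would have a similar effect on compound 1, which carries its methyl at a different place.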